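Adding a hydroxy group to a deoxynucleoside: toxicity expected to stay low

A few compounds are considered here, and "the series" means these few. Any claim that something is new, unique, unknown or untested is made for them only; others in the source may bear on it.

Measured compounds:
- compound 1, `CCCCCCC#Cc1cc2cn([C@H]3C[C@H](O)[C@@H](CO)O3)c(=O)nc2o1`, 138000 nM in a functional assay on HEL cells (Homo sapiens) for cytotoxicity; on this read-out lower numbers stand for higher toxicity in this test and higher numbers for lower toxicity in this test
- compound 2, `CCCCCCCCC#Cc1cc2cn([C@H]3C[C@H](O)[C@@H](CO)O3)c(=O)nc2o1`, 77000 nM in this assay
- compound 3, `CCCCCCC#Cc1cc2cn([C@@H]3O[C@H](CO)[C@@H](O)[C@@H]3O)c(=O)nc2o1`, a limit of > 53000 nM in this assay

Compound 2 differs from compound 1 by ethyl in place of hydrogen on a saturated chain carbon, six bonds along the chain from a triple-bonded carbon. That change gave a 1.8-fold lower number from compound 1 to compound 2 (0.25 log units; within the scatter), so the two stand level within the usual scatter of this assay. Compound 3 differs from compound 1 by hydroxy in place of hydrogen on a saturated ring carbon, and its value is a limit, not a number. The step that the limit leaves unreadable from compound 1 to compound 3 is therefore unreadable in size; what is known is the limit of > 53000 nM in this assay, at which 1 of the 3 values shown sits.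

Compound 4, `CCCCCCCCC#Cc1cc2cn([C@@H]3O[C@H](CO)[C@@H](O)[C@H]3O)c(=O)nc2o1`, is not yet measured. It differs from compound 2 by hydroxy in place of hydrogen on a saturated ring carbon, the same change that leads from compound 1 to compound 3, made at the same place. Since compound 2 sits within the scatter of compound 1, and the change from compound 1 ended at a limit, the step is expected to be small or to reach the limit again. The expected step is a 1.4-fold higher number from compound 2 to compound 4 (0.15 log units; within the scatter). Compound 4 is expected to give about 110000 nM, most likely between 45000 nM and 270000 nM.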

Compound 4, half-maximal cytotoxic concentration: 62000 nM
Compound 4: the middle estimate sits 1.8-fold (0.25 log units) above what was measured; the range from low to high includes it.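

In this assay, placing a hydroxy group on the saturated ring carbon of compound 2 gave a 1.2-fold lower number from compound 2 to compound 4 (0.09 log units; within the scatter), so the two compounds stand level and the change leaves this read-out where it was on this core. With the chain of compound 1, the same kind of change leads to compound 3, whose value is a limit and not a number, so that step cannot be read in size: the limit of > 53000 nM in this assay, at which 1 of the 4 values shown sits. Among these compounds, this gives only one readable step, which shows that the hydroxy group made no difference beyond the scatter on one core, but does not show that the step has the same size on the other.

The compounds shown leave open whether an amine or a methoxy group on the same ring carbon would also stand level with compound 2 in this assay. They also leave open how the hydroxy change would behave with a chain longer than that of compound 2.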